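Aryl replacement on the oxime ether series

The compounds below may be only part of what the source reports. "The series", "measured", "known", "first", "only" and "open" are said of these compounds alone.

Measured so far in a functional assay on HEK293 cells with D(4) dopamine receptor (Homo sapiens) as the target, read by FLIPR; on this read-out lower numbers stand for smaller maximal responses and higher numbers for larger maximal responses:
Compound 1, `Cc1ccccc1/C(CCN1CCN(c2ccccn2)CC1)=N/O`, gives 82%.
Compound 2, `CO/N=C(\CCN1CCN(c2ccccn2)CC1)c1ccccc1C`, gives 80%.
Compound 3, `CO/N=C(/CCN1CCN(c2ccccn2)CC1)c1ccccc1C`, gives 72%.

Compound 2 stands second highest of the three. Its nearest neighbour is compound 1, with the step of a number 2 percentage points lower from compound 1 to compound 2 (within the scatter); furthest is compound 3, with the step of a number 8 percentage points lower from compound 2 to compound 3 (within the scatter), the only distinction between those two being that (the fact that compounds 2 and 3 differ only in the configuration as drawn). Both measured steps fall inside the scatter, so the three compounds occupy a single narrow band in this assay.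

Compound 4, `CO/N=C(\CCN1CCN(c2ccccn2)CC1)c1ccc(Cl)c(Cl)c1`, differs from compound 2 by 3,4-dichlorophenyl in place of 2-methylphenyl on a carbon with a double bond to nitrogen. Neither measured step touches the aryl group on the imine carbon: one concerns the oxime oxygen, the other the double-bond configuration, and both left the response essentially unchanged. Going by the values given here, no measured step therefore bears directly on this change, and with the series so flat the expectation is for compound 4 to remain in the same band, with a step of a number 2 percentage points lower from compound 2 to compound 4 (within the scatter) that is expected not to exceed the scatter. The estimate for compound 4 in this assay is 78%, in the expected range 60% to 95%.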

Compound 4, largest response reached (reported as efficacy), in percent of the reference or control that the assay uses: 79%
Beside the measured number, compound 4's estimate is 1 percentage points below it; low and high end bracket the measured number.
By their numbers in this assay, from the lowest: compounds 3, 4, 2 and 1 (each within the scatter of the next).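

Going by these compounds alone, the first measured change at the aryl group, in this assay, gives a number 1 percentage points lower from compound 2 to compound 4 (within the scatter), so this position accepts 3,4-dichlorophenyl in place of 2-methylphenyl on a carbon with a double bond to nitrogen without leaving the band set by compounds 1, 2 and 3. The swap removes one group and brings in another in a single step, so the result covers the whole exchange and does not separate the loss of the methyl from the gain of the two chlorines. Nothing available accounts for this flat outcome at the aryl position.

As far as these compounds go, whether 3,4-dichlorophenyl gives the same response with the double bond drawn as in compound 3, or with the free oxime of compound 1, remains open. Also open, from the compounds shown here alone, is whether a phenyl carrying a carboxylic acid or a primary amine stays in this band.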